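Series notes: pendant aryl groups on a shared acid core

A few compounds are considered here, and "the series" means these few. Any claim that something is new, unique, unknown or untested is made for them only; others in the source may bear on it.

Measured so far:
compound 1 `O=C(O)/C=C/c1ccc2noc(-c3ccc(OC(F)(F)F)cc3)c2c1` — 8370 nM
compound 2 `Cc1cccc(-c2onc3ccc(/C=C/C(=O)O)cc23)c1` — 3590 nM
compound 3 `O=C(O)c1ccc2noc(-c3ccc(-c4cccnc4)cc3)c2c1` — 610 nM

All values come from an assay for inhibition of inositol hexakisphosphate kinase 3 (Homo sapiens), read by colorimetric assay, coupled enzyme assay and malachite green, with a stated time of 120 min, in the presence of a further agent that is not named here; on this read-out lower numbers stand for stronger inhibition and higher numbers for weaker inhibition. Compound 3 stands lowest of the three numbers; compound 2 is nearest, with a higher number that lies beyond the scatter, and compound 1 is furthest, also beyond the scatter. Among the measured compounds shown here, compounds 1 and 2 differ from compound 3 both in how the acid is attached and in the pendant aryl group, so no measured pair differs in a single place, and the separate contribution of the aryl group cannot be read from these values.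

Compound 4 `O=C(O)c1ccc2noc(-c3ccc(Oc4ccccc4)cc3)c2c1` is not yet measured. It differs from compound 3 by phenoxy in place of pyridin-3-yl on an aromatic carbon. For the measured compounds named here, no measured pair shows the effect of this exchange. The change swaps one aromatic ring for another at the same place on the shared core, and the expectation is a step in this assay of modest size at most, with a somewhat higher number judged more likely than a lower one; on that basis a 1.5-fold higher number from compound 3 to compound 4 (0.17 log units; within the scatter) is expected. Compound 4 is estimated at 900 nM, with a range from 300 nM to 3000 nM.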

Compound 4, half-maximal inhibitory concentration: 550 nM
Compound 4: middle estimate off by 1.6-fold (0.21 log units), on the high side; measured number inside the range.
By their numbers in this assay, from the lowest: compounds 4 and 3 (each within the scatter of the next); then compound 2; then compound 1.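

In this assay, among the compounds shown here, phenoxy in place of pyridin-3-yl on an aromatic carbon, para to a large group, gives a 1.1-fold lower number from compound 3 to compound 4 (0.04 log units; within the scatter); this is the first comparison that differs in one place only. At this place, therefore, a six-membered aromatic ring of carbon only, joined through the oxygen of phenoxy, and the ring with one hetero atom in pyridin-3-yl give values within the scatter of each other, so the hetero atom of that ring is not required for a value of this size. Nothing at hand explains why the two groups read alike.

As far as these compounds go, whether a saturated ring such as morpholine, or a simple amine, would read like these two aromatic groups at the same place remains open, as does the outcome of replacing the carboxylic acid on the shared core with an amide. Compounds 1 and 2 each differ from compound 3 and compound 4 in more than one place, so the separate contribution of how the acid is attached cannot be read from these values.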